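Adding Chlorine to a Potent Mer Inhibitor

This account rests on a few compounds, and the source may have more. Where it says the series, first, only, none or still open, it means among the compounds named here.

Compound 1 `CN(Cc1ccc2nccn2c1)c1nnc(-c2ccccc2)o1`: 15800 nM
Compound 2 `Cc1nn(C)c(C)c1-c1ccc(-c2nnc(N(C)Cc3ccc4nccn4c3)o2)cc1`: 31.6 nM

For the measured compounds named here, both compounds were tested in an assay on isolated protein for inhibition of tyrosine-protein kinase Mer (Homo sapiens), read by LC-MS (a lower number here means a stronger inhibitor, a higher number a weaker inhibitor), and compound 2 gives the lowest of the two numbers, its only neighbour being compound 1 at a much higher value. Going by the values given here, the single measured step, a 500-fold lower number from compound 1 to compound 2 (2.70 log units; beyond the scatter), came with 1,3,5-trimethyl-1H-pyrazol-4-yl in place of hydrogen on an aromatic carbon, so the whole of what is known about this series rests on that one large change.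

Compound 3 `Cc1nn(C)c(C)c1-c1ccc(-c2nnc(N(C)Cc3ccc4nccn4c3)o2)c(Cl)c1` keeps everything in compound 2 and differs only in one spot: chloro in place of hydrogen on an aromatic carbon. Among the compounds with values here, no measured step involves a chloro group, and the one step available concerns a quite different, larger group, so it offers no direct guide. Without any evidence pointing either way, the expectation is a step that stays within the scatter, a 1.1-fold lower number from compound 2 to compound 3 (0.02 log units; within the scatter). Compound 3 is therefore estimated at 30 nM, with a plausible range from 8 nM to 120 nM.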

Compound 3, half-maximal inhibitory concentration: 2.51 nM
The estimate for compound 3 lay 12-fold (1.08 log units) above the measured number, outside the stated range (below it).
By their numbers in this assay, from the lowest: compound 3; then compound 2; then compound 1.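

In this assay, a single chlorine on this aromatic carbon, ortho to a large group and meta to the 1,3,5-trimethyl-1H-pyrazol-4-yl group, gives a 13-fold lower number from compound 2 to compound 3 (1.10 log units; beyond the scatter). For the compounds shown here, the earlier compounds carry only hydrogen here, so this is the first sign that the position responds strongly to a change, and that one added heavy atom can move an already low number much further. Nothing measured here explains this gain.

Going by these compounds, how a fluoro, methyl or methoxy group on the same carbon would compare with chloro remains open. It is also unknown whether chloro would give a step of similar size in compound 1, which lacks the 1,3,5-trimethyl-1H-pyrazol-4-yl group.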